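Swapping the acyl aryl on an analogue already at the limit

A few compounds are considered here, and "the series" means these few. Any claim that something is new, unique, unknown or untested is made for them only; others in the source may bear on it.

Compound 1 `CN(C(=O)NC(=O)c1ccc(Cl)cc1Cl)c1nc(C(F)(F)F)c(C(=O)N/N=C/c2cccc(C(F)(F)F)c2)s1` and compound 2 `CN(C(=O)NC(=O)c1ccc(Cl)cc1Cl)c1nc(C(F)(F)F)c(C(=O)N/N=C/c2cc(C(F)(F)F)cc(C(F)(F)F)c2)s1` share one core and differ only on the benzylidene ring. In a functional assay on HeLa cells (Homo sapiens) for inhibition, read by MTT assay, with a stated time of 72 h (a lower number here means a stronger inhibitor, a higher number a weaker inhibitor), compound 1 gives 9.6 ug/mL. In this assay compound 2 gives > 100 ug/mL, which is a limit of the assay and not a number. Compound 2 thus sits at the limit of > 100 ug/mL in this assay, at which 1 of the 2 values shown sits. Going by the values given here, the single measured step, an at least 10-fold higher number from compound 1 to compound 2 (1.01 log units; beyond the scatter), is large and beyond the scatter.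

Compound 3 `CN(C(=O)NC(=O)c1ccc(C(F)(F)F)cc1)c1nc(C(F)(F)F)c(C(=O)N/N=C/c2cc(C(F)(F)F)cc(C(F)(F)F)c2)s1` keeps the bis(trifluoromethyl)benzylidene of compound 2 and differs from it at the acyl end: 4-(trifluoromethyl)phenyl in place of 2,4-dichlorophenyl on a carbonyl carbon. Among the compounds with values here, no measured step concerns this place; the step from compound 1 to compound 2 lies on the other aromatic ring, so it gives no guide to the direction or size of the present change. With compound 2 already at the limit, compound 3 is expected to remain at or near it in this assay. Compound 3 is therefore estimated at 100 ug/mL, with a range from 30 ug/mL to 300 ug/mL. The step of a number no higher from compound 2 to compound 3 (the limit leaves the size open) is expected to show no change beyond the scatter.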

Compound 3, half-maximal inhibitory concentration: 5.78 ug/mL
For compound 3 the middle estimate is 17-fold (1.24 log units) above the measured one; measured number below the stated range.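

The change from 2,4-dichlorophenyl to 4-(trifluoromethyl)phenyl on a carbonyl carbon gives an at least 17-fold lower number from compound 2 to compound 3 (1.23 log units; beyond the scatter), so the acyl aryl is a place that counts in this assay, and the earlier step on the benzylidene ring could not show this. The bis(trifluoromethyl)benzylidene of compound 2 therefore does not by itself hold a compound at the limit, for compound 3 carries the same ring and gives a measured number. The value of compound 2 is a limit and not a number, so the step has a floor but no fixed size: the limit of > 100 ug/mL in this assay, at which 1 of the 3 values shown sits.

The compounds give no reason for the step, and they do not tell whether the added trifluoromethyl on the benzylidene ring would cost as much with 4-(trifluoromethyl)phenyl at the acyl end as it does with 2,4-dichlorophenyl. Also open, as far as these compounds go, is how this place would respond to an unsubstituted phenyl, or to an amine or a carboxylic acid in place of the trifluoromethyl on the acyl ring of compound 3.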